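A few compounds are considered here, and "the series" means these few. Any claim that something is new, unique, unknown or untested is made for them only; others in the source may bear on it.

Compounds measured in a functional assay on MCF7 cells (Homo sapiens) for antiproliferative activity, read by sulforhodamine B assay, with a stated time of 48 h; a lower number here means a stronger inhibitor, a higher number a weaker inhibitor:
compound 1, `CCCC(=O)Nc1ccc(S(=O)(=O)Oc2ccccc2C(C)C)cc1`, gives 6600 nM;
compound 2, `CC(C)c1ccccc1OS(=O)(=O)c1ccc(NC(=O)CCl)cc1`, gives 2900 nM;
compound 3, `CC(C)c1ccccc1OS(=O)(=O)c1ccc(NC(=O)CCCCl)cc1`, gives 5200 nM.

Compound 3 holds the second-highest number of the three, closest to compound 1 and furthest from compound 2, though both gaps lie within the scatter.

Compound 4, `CC(C)c1ccccc1OS(=O)(=O)c1ccc(NC(=O)NC2CCCC2)cc1`, is obtained from compound 3 by this change: cyclopentylamino in place of 3-chloropropyl on a carbonyl carbon. The amide of compound 3 thus becomes a urea bearing a five-membered carbon ring.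

For the measured compounds named here, none of the measured steps bears directly on this change. The steps of a 2.3-fold lower number from compound 1 to compound 2 (0.36 log units; beyond the scatter), a 1.3-fold lower number from compound 1 to compound 3 (0.10 log units; within the scatter) and a 1.8-fold higher number from compound 2 to compound 3 (0.25 log units; within the scatter) all vary a chloro substituent along the saturated chain, and only the first of them exceeds the scatter. Going by the values given here, no measured pair shows an amino group or a ring on the carbonyl carbon. The series therefore offers no basis for a directed expectation in this assay, and the expected step of a 1.0-fold lower number from compound 3 to compound 4 (0.02 log units; within the scatter) is set at no change beyond the scatter, with a wide range.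

Compound 4 is expected to give about 5000 nM in this assay, estimated between 1500 nM and 16000 nM.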

Compound 4, half-maximal inhibitory concentration: 6200 nM
Estimate against measurement, compound 4: 1.2-fold (0.09 log units) below; measured number inside the range.
By their numbers in this assay, from the lowest: compounds 2, 3, 4 and 1 (each within the scatter of the next, the first and the last beyond it).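

In this assay, cyclopentylamino in place of 3-chloropropyl on the carbonyl carbon turns the amide into a urea and gives a 1.2-fold higher number from compound 3 to compound 4 (0.08 log units; within the scatter), so this position takes a five-membered carbon ring and an added hydrogen-bond donor with no change beyond the scatter. Against the propyl group without chlorine the result is the same, with a 1.1-fold lower number from compound 1 to compound 4 (0.03 log units; within the scatter), whereas against chloromethyl the series shows a 2.1-fold higher number from compound 2 to compound 4 (0.33 log units; beyond the scatter), a modest step and the only one of the three beyond the scatter. No measured data on these compounds offer an explanation for these steps.

The compounds shown leave open whether the ring or the urea nitrogen matters on its own, as a cyclopentyl amide and an open-chain propylamino urea would separate the two. Also open, going by these compounds, is how a larger ring such as cyclohexyl, or a terminal amine or carboxylic acid on the chain, would read in this assay, since the series holds none of these groups.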